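The source may report more compounds than this note shows. Statements on the series, on what has been measured and on what is new or still open speak of the compounds shown alone.

Two measured compounds set the scene. In a functional assay on OVCAR-8 cells (Homo sapiens) for inhibition, read by sulforhodamine B assay, with a stated time of 48 h, tested at 1 uM (on this read-out higher numbers stand for a weaker effect at the one concentration tested and lower numbers for a stronger effect), compound 1 `COc1cc(Cl)cc(-c2nn(-c3cccc(NC(=O)Nc4ccc(Cl)c(C(F)(F)F)c4)c3)cc2-c2ccncc2)c1` gives 43%. In this assay, among the measured compounds shown here, compound 2 `COc1cc(Cl)cc(-c2nn(-c3cccc(NC(=O)Nc4cccc(C(F)(F)F)c4)c3)cc2-c2ccncc2)c1` gives 54%, the higher of the two numbers, and the only measured step is a number 11 percentage points higher from compound 1 to compound 2 (beyond the scatter). Compound 3 `COc1cc(Cl)cc(-c2nn(-c3cccc(NC(=O)c4cccc(C(F)(F)F)c4)c3)cc2-c2ccncc2)c1` has not been measured. It differs from compound 2 by 3-(trifluoromethyl)phenyl in place of (3-(trifluoromethyl)phenyl)amino on a carbonyl carbon. For the measured compounds named here, the measured step from compound 1 to compound 2 concerns hydrogen in place of chloro on an aromatic carbon, a different place, so no measured step bears on an exchange at the carbonyl carbon, and the data give no direction for it. The estimate for compound 3 is therefore centred near the value of compound 2 with a wide range: in this assay compound 3 is expected to give 58%, between 35% and 85%. The step of a number 4 percentage points higher from compound 2 to compound 3 (within the scatter) that this estimate means is expected to stay within the scatter.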

Compound 3, a percentage reported as activity, at one concentration (the size of the read-out at that concentration, not a potency): 93%
Estimate against measurement, compound 3: 35 percentage points below; measured number outside the range, above it.
By their numbers in this assay, from the lowest: compound 1; then compound 2; then compound 3.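

At this carbonyl carbon, the exchange of (3-(trifluoromethyl)phenyl)amino for 3-(trifluoromethyl)phenyl in this assay gives a number 39 percentage points higher from compound 2 to compound 3 (beyond the scatter), a much weaker effect and a far larger change than the loss of chloro had produced. The same kind of exchange, starting from the chloro-bearing (4-chloro-3-(trifluoromethyl)phenyl)amino group, gives a number 50 percentage points higher from compound 1 to compound 3 (beyond the scatter), so the amino nitrogen in this position matters more to the read-out than the chloro does. The leaving group counts 1 hydrogen-bond donor and the entering group 0 hydrogen-bond donors, but nothing available explains the size of the step.

From the compounds shown here alone, whether an oxygen atom or a methylene group in place of the amino nitrogen would retain the stronger effect remains open. So does whether a chloro on the aromatic ring of compound 3 would change its number at all.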